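This account rests on a few compounds, and the source may have more. Where it says the series, first, only, none or still open, it means among the compounds named here.

Measured compounds: compound 1 `CC(Oc1ccccc1)C(=O)Nc1ccc(OCC(=O)O)c(F)c1` with 35.7%; compound 2 `CC(C)(C)c1cccc(OCC(=O)Nc2ccc(OCC(=O)O)c(F)c2)c1` with 40.2%.

In a functional assay on CHO cells for agonist activity at Free fatty acid receptor 1 (Homo sapiens), read by FLIPR, tested at 100 nM (a lower number here means a weaker effect, a higher number a stronger effect of the compound at the concentration tested), compound 2 gives 40.2%, the higher of the two numbers, though compound 1 lies within the scatter of it. Compound 3 `CC(Oc1cccc(C(C)(C)C)c1)C(=O)Nc1ccc(OCC(=O)O)c(F)c1` differs from compound 2 by one change: methyl in place of hydrogen on a saturated chain carbon bound to a carbonyl carbon and an oxygen on an aromatic ring. Within the data shown here, no step between measured compounds is available to size such a change, so the expectation for compound 3 rests on compound 2 alone and on the two measured values lying close together. The step from compound 2 to compound 3 is expected to be a number 1.8 percentage points higher from compound 2 to compound 3 (within the scatter), not beyond the scatter. Compound 3 is thus estimated at 42%, within 25% to 60%.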

Compound 3, a percentage reported as activity, at one concentration (the size of the read-out at that concentration, not a potency) in the Free fatty acid receptor 1 assay: 32.8%
For compound 3 the middle estimate is 9.2 percentage points above the measured one; the range from low to high includes it.
By their numbers in the Free fatty acid receptor 1 assay, from the lowest: compounds 3, 1 and 2 (each within the scatter of the next).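

Among these compounds, in the Free fatty acid receptor 1 assay, compound 3 gives 32.8%; methyl in place of hydrogen on a saturated chain carbon bound to a carbonyl carbon and an oxygen on an aromatic ring gives a first sized step at this position (a number 7.4 percentage points lower from compound 2 to compound 3 (within the scatter)), and tert-butyl in place of hydrogen on an aromatic carbon gives another (a number 2.9 percentage points lower from compound 1 to compound 3 (within the scatter)). In a physicochemical assay for lipophilicity, using the shake flask method, at pH 7.4 (on this read-out higher numbers stand for higher lipophilicity and lower numbers for lower lipophilicity), compound 2 gives 0.35 and compound 3 gives 0.63, and the methyl step is also within the scatter (a number 0.28 log units higher from compound 2 to compound 3 (within the scatter)). Nothing available here accounts for these steps. Going by these compounds, whether an amine or a longer chain at that saturated carbon would move either read-out beyond the scatter remains open.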